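A few compounds are considered here, and "the series" means these few. Any claim that something is new, unique, unknown or untested is made for them only; others in the source may bear on it.

Measured so far:
- compound 1, `Nc1nc(-c2ccc(C(F)F)o2)nc2sc(Cc3ccccc3)cc12`: 3000 nM
- compound 2, `COc1cccc(-c2nc(N)c3cc(Cc4ccccc4)sc3n2)c1`: 266 nM

Both compounds share one core and differ in a single group. Among the compounds with values here, in a functional assay on CHO-K1 cells for antagonist activity at adenosine receptor A1 (Homo sapiens), read by a beta-galactosidase reporter and cAMP accumulation, with stated times of 15 min and 6 h (on this read-out higher numbers stand for weaker inhibition and lower numbers for stronger inhibition), compound 1 gives 3000 nM, and compound 2 gives 266 nM, the lowest of the two numbers and therefore the stronger blocker of the pair; the only measured step is an 11-fold lower number from compound 1 to compound 2 (1.05 log units; beyond the scatter).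

Compound 3, `Nc1nc(-c2cccnc2)nc2sc(Cc3ccccc3)cc12`, has not been measured. It differs from compound 2 by pyridin-3-yl in place of 3-methoxyphenyl on an aromatic carbon. Within the data shown here, no measured step swaps one six-membered aromatic group for another at this position, so the single measured step gives only a rough guide: it shows that this position tolerates a change of group with a large shift in this assay, but not in which direction a pyridin-3-yl group would move the number. Among the measured compounds shown here, with no direct precedent, a modest step is expected, a 1.9-fold higher number from compound 2 to compound 3 (0.27 log units; within the scatter), leaning toward a somewhat higher number. Compound 3 is therefore estimated at 500 nM, with a plausible range from 120 nM to 2000 nM.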

Compound 3, inhibition constant: 1420 nM
Compound 3: the middle estimate sits 2.8-fold (0.45 log units) below what was measured; low and high end bracket the measured number.
By their numbers in this assay, from the lowest: compound 2; then compound 3; then compound 1.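

In this assay, one six-membered aromatic ring cannot simply stand in for another at this position: the change to pyridin-3-yl gives a 5.3-fold higher number from compound 2 to compound 3 (0.73 log units; beyond the scatter). Pyridin-3-yl still does better than 5-(difluoromethyl)furan-2-yl, with a 2.1-fold lower number from compound 1 to compound 3 (0.32 log units; beyond the scatter), so the three groups fall into a clear order, and 3-methoxyphenyl gives the strongest inhibition of the three. No evidence is available on why the groups rank this way.

The 3-methoxyphenyl and pyridin-3-yl groups differ in two ways, the methoxy group and the ring nitrogen, and the compounds shown cannot separate these two changes. From the compounds shown here alone, it also remains open how a plain phenyl ring, which has neither feature, or an amine at the same place would read in this assay.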